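Metabolic stability of a urea analogue in a sulfonyl-amide series

The compounds below may be only part of what the source reports. "The series", "measured", "known", "first", "only" and "open" are said of these compounds alone.

Measured so far:
- Compound 1 `CC(C)(C)OC(=O)NCCS(=O)(=O)NC(=O)c1ccc(Nc2nc(NC3(c4ccc(Cl)cc4)CC3)nc(OCC(F)(F)F)n2)cc1`: 93%
- Compound 2 `O=C(NS(=O)(=O)CCNC(=O)C1CC1)c1ccc(Nc2nc(NC3(c4ccc(Cl)cc4)CC3)nc(OCC(F)(F)F)n2)cc1`: "not active" (no number reported) (no single number reported)
- Compound 3 `CC(=O)NCCS(=O)(=O)NC(=O)c1ccc(Nc2nc(NC3(c4ccc(Cl)cc4)CC3)nc(OCC(F)(F)F)n2)cc1`: 100%

In an ADME assay on microsomes from liver (Rattus norvegicus) for metabolic stability, with a stated time of 10 min (on this read-out lower numbers stand for a less stable compound and higher numbers for a more stable compound), compound 3 holds the highest of the two numbers, yet its nearest neighbour, compound 1, sits only a small distance away, as the step of a number 7 percentage points higher from compound 1 to compound 3 (within the scatter) shows to be within the scatter. Compound 4 `CNC(=O)NCCS(=O)(=O)NC(=O)c1ccc(Nc2nc(NC3(c4ccc(Cl)cc4)CC3)nc(OCC(F)(F)F)n2)cc1` is not yet measured; it differs from compound 3 by methylamino in place of methyl on a carbonyl carbon. Among the compounds with values here, the one step that bears on this change, a number 7 percentage points higher from compound 1 to compound 3 (within the scatter), exchanged a group on the same carbonyl carbon and stayed within the scatter. The step of a number 6 percentage points lower from compound 3 to compound 4 (within the scatter) is therefore expected to be small as well, with no clear direction beyond the scatter. Compound 4 is estimated at 94%, within a range from 78% to 100%.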

Compound 4, percent of the compound remaining: 100%
Beside the measured number, compound 4's estimate is 6 percentage points below it; the measured number falls inside the stated range.
By their numbers in this assay, from the lowest: compounds 1, 3 and 4 (each within the scatter of the next).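

Replacing methyl with methylamino on the carbonyl carbon gives no change at the digits printed from compound 3 to compound 4 (within the scatter) in this assay, and replacing tert-butoxy with methylamino gives a number 7 percentage points higher from compound 1 to compound 4 (within the scatter). Within the data shown here, a group that puts a nitrogen and a hydrogen-bond donor on this carbonyl carbon therefore reads like both the methyl and the tert-butoxy compounds, which the earlier compounds could not show. Nothing here explains why these groups read alike.

From the compounds shown here alone, whether a free amine, a carboxylic acid or a longer chain here would also read alike stays open. Compound 2 has no number, so how it compares cannot be read.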